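The compounds below may be only part of what the source reports. "The series", "measured", "known", "first", "only" and "open" are said of these compounds alone.

Of the compounds shown here, three have so far been measured in a functional assay on NCI-H522 cells (Homo sapiens) for inhibition, read by sulforhodamine B assay, with a stated time of 48 h, tested at 10 uM; a higher number here means more inhibition of growth at the concentration tested, a lower number less inhibition of growth. Compound 1 `COc1cc(-c2nc(N)n(CC(=O)Nc3ccc(/C(C)=N\O)cc3)n2)cc(OC)c1OC` gives 29.2% in this assay, compound 2 `C/C(=N/O)c1ccc(NC(=O)Cn2nc(-c3ccccc3)nc2N)cc1` gives 30%, and compound 3 `c1ccc(-c2nc3sc(-c4ccccc4)cn3n2)cc1` gives 19%. Compound 3 stands lowest of the three numbers: the nearest to it is compound 1, whose number is higher by a margin beyond the usual scatter, and the furthest is compound 2, whose number is higher by a margin that also lies beyond the scatter.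

Compound 4 `Clc1ccc(-c2cn3nc(-c4ccccc4)nc3s2)cc1` has not yet been measured in this assay. It differs from compound 3 in one place: chloro in place of hydrogen on an aromatic carbon. Within the data shown here, no two of the measured compounds differ from each other in a single place, so there is no measured step of this kind to lean on. In this assay the step is expected to be small, a number 5 percentage points higher from compound 3 to compound 4 (within the scatter), and not beyond the scatter in either direction. Compound 4 is therefore estimated to give about 24% in this assay, within a range from 10% to 40%.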

Compound 4, percent growth inhibition at one concentration: 29%
Estimate against measurement, compound 4: 5 percentage points below; measured number inside the range.
By their numbers in this assay, from the lowest: compounds 3, 4, 1 and 2 (each within the scatter of the next, the first and the last beyond it).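

In this assay, among these compounds, chloro in place of hydrogen on an aromatic carbon gives a number 10 percentage points higher from compound 3 to compound 4 (within the scatter), the first step in this set that changes only one place. Among the compounds shown here, it shows that this position, para to a large group on the six-membered aromatic ring of carbon only, can carry a chlorine atom with no change beyond the scatter, something the earlier compounds could not show, as no two of them formed such a pair. Nothing measured here accounts for the size of this step.

The compounds shown leave open whether an amine, a carboxylic acid or a longer chain such as butyl in this same place would move the number beyond the scatter. A single step sets no trend across groups at this position.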